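The source may report more compounds than this note shows. Statements on the series, on what has been measured and on what is new or still open speak of the compounds shown alone.

Measured in an ADME assay on HepG2 cells (Homo sapiens) for cytotoxicity, read by luminescence, CellTiter-Glo and ATP content, with a stated time of 72 h; on this read-out lower numbers stand for an effect already at smaller amounts and higher numbers for an effect only at larger amounts of compound:
compound 1, `COc1ccc(F)cc1CNCCCNc1ccnc2cc(Cc3ccc(F)cc3Cl)ccc12`: 2460 nM
compound 2, `COc1ccc(F)cc1CNCCCNc1ccnc2cc(Cc3ccc(F)cc3)ccc12`: 3530 nM
compound 3, `COc1ccc(F)cc1CNCCCNc1ccnc2cc(Oc3ccccc3)ccc12`: 1500 nM

Compound 3 differs from compound 2 in the group on the shared core: phenoxy in place of 4-fluorobenzyl on an aromatic carbon, and this gave a 2.4-fold lower number from compound 2 to compound 3 (0.37 log units; beyond the scatter). Compound 1 differs from compound 2 by chloro in place of hydrogen on an aromatic carbon, which gave a 1.4-fold lower number from compound 2 to compound 1 (0.16 log units; within the scatter). The unmeasured compound 4, `COc1ccc(F)cc1CNCCCNc1ccnc2cc(Oc3ccc(Cl)cc3)ccc12`, differs from compound 3 by chloro in place of hydrogen on an aromatic carbon. This is the same kind of change as that from compound 2 to compound 1, but the surroundings differ: there the chloro entered ortho to a large group and meta to a fluoro group, here it enters para to a large group. From compound 3 to compound 4 a step of about the same small size is expected, a 1.3-fold lower number from compound 3 to compound 4 (0.10 log units; within the scatter), resting on compound 1 having shown a 1.4-fold lower number from compound 2 to compound 1 (0.16 log units; within the scatter). For compound 4 in this assay the estimate is 1200 nM, between 500 nM and 3000 nM.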

Compound 4, half-maximal effective concentration: 4500 nM
Compound 4: the middle estimate sits 3.8-fold (0.57 log units) below what was measured, outside the stated range (above it).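

On the core of compound 3, chloro in place of hydrogen gave a 3.0-fold higher number from compound 3 to compound 4 (0.48 log units; beyond the scatter), so in this assay this change does not carry over unchanged from the core of compound 2: the same change on two cores in this assay, a 1.4-fold lower number (0.16 log units; within the scatter) from compound 2 to compound 1 and a 3.0-fold higher number (0.48 log units; beyond the scatter) from compound 3 to compound 4, 4.3-fold (0.63 log units) apart, beyond the scatter of two such steps. The steps between the two cores that end at compound 4 stay small, with a 1.3-fold higher number from compound 2 to compound 4 (0.11 log units; within the scatter) and a 1.8-fold higher number from compound 1 to compound 4 (0.26 log units; within the scatter). With one pair on each core and the chloro placed differently in each pair, this shows that the step cannot simply be transferred, but not whether the core or the chloro's place decides its size.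

As far as these compounds go, it remains open how a bromo or a methoxy in place of the chloro of 4-chlorophenoxy would behave. From the compounds shown here alone, a nitrile at that place is equally open.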